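The source may hold more compounds than are shown below. What is called first, only, known or untested is meant among the compounds shown, and "the series" means these compounds.

Compound 3 `N#CC1=C(N)Oc2c(N)cc3nc4ccccc4nc3c2C12C(=O)N(Cc1cnnn1-c1ccccc1Br)c1ccccc12` carries a 2-bromophenyl group on an aromatic nitrogen and an amino group on its core. Among the measured compounds shown here, in a functional assay on MCF7 cells (Homo sapiens) for antiproliferative activity, read by MTT assay, with a stated time of 48 h (a higher number here means a weaker inhibitor, a lower number a stronger inhibitor), compound 3 gives 30700 nM, the only number among the three values shown. The other two values are limits of the assay. Compound 1 `Cc1ccc(C)c(-n2nncc2CN2C(=O)C3(C(C#N)=C(N)Oc4c3c3nc5ccccc5nc3c3ccccc43)c3ccccc32)c1` bears a 2,5-dimethylphenyl group in that place and lacks the amino group. In this assay compound 1 returns only a limit, > 50000 nM. Compound 2 `N#CC1=C(N)Oc2c(c3nc4ccccc4nc3c3ccccc23)C12C(=O)N(Cc1cnnn1-c1ccc(F)c(Cl)c1)c1ccccc12`, with a 3-chloro-4-fluorophenyl group, likewise returns only a limit, > 50000 nM. The step that the two limits leave unreadable from compound 1 to compound 2 therefore cannot be read, since the limit of > 50000 nM in this assay, at which 2 of the 3 values shown sit, covers both of its values.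

Compound 4 `Cc1cc(C)c(-n2nncc2CN2C(=O)C3(C(C#N)=C(N)Oc4c(N)cc5nc6ccccc6nc5c43)c3ccccc32)c(C)c1` differs from compound 3 by 2,4,6-trimethylphenyl in place of 2-bromophenyl on an aromatic nitrogen. For the measured compounds named here, no measured step that swaps the aryl group on this nitrogen has a readable size, so no direction beyond the scatter can be drawn from the data. Compound 1 does show that a methyl-bearing phenyl in this place gives > 50000 nM. Compound 4 is therefore expected to remain weak, with an estimated 45000 nM in this assay, between 20000 nM and 110000 nM, an expected step of a 1.5-fold higher number from compound 3 to compound 4 (0.17 log units; within the scatter) that may well end at the limit.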

Compound 4, half-maximal inhibitory concentration: > 50000 nM
Compound 4: only a limit was reported; the forecaster's own chance of this, stated with the estimate: 55%; middle value at least 1.1-fold (0.04 log units) from the limit.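

Among the compounds shown here, compound 4 gives the first step on this aromatic nitrogen that has a readable floor, which the earlier pair could not give: in this assay, putting 2,4,6-trimethylphenyl in place of 2-bromophenyl gives an at least 1.6-fold higher number from compound 3 to compound 4 (0.21 log units; that floor lies within the scatter). From the compounds shown here alone, that floor lies within the scatter, so the step sets no direction beyond it, and its true size stays unknown. For the compounds shown here, the value of compound 4 is a limit, and compound 3 remains the only compound with a number: the limit of > 50000 nM in this assay, at which 3 of the 4 values shown sit.

No pair shown differs only in the amino group on the core, so its contribution stays unread. Going by these compounds, it also remains open whether a plain phenyl, or a phenyl carrying an amine or a carboxylic acid, on this nitrogen would give a lower number in this assay than compound 3 gives.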